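Notes on the step from compound 3 to compound 4

The source may report more compounds than this note shows. Statements on the series, on what has been measured and on what is new or still open speak of the compounds shown alone.

- compound 1 `COc1ccc(NC(=O)c2ccc(OCCCCl)c([N+](=O)[O-])c2)cc1`: 39700 nM
- compound 2 `CN(C)C1CCN(Cc2ccc(NC(=O)c3ccc(OCCCCl)c([N+](=O)[O-])c3)cc2C(F)(F)F)C1`: 5800 nM
- compound 3 `CCC(=O)Nc1cc(C(=O)Nc2ccc(OC)cc2)ccc1OC(C)C`: 113000 nM

In a toxicity assay on Huh-7.5 cells (Homo sapiens) for inhibition, read by MTT assay, with a stated time of 96 h (a lower number here means that less compound is tolerated, a higher number that more compound is tolerated), compound 3 gives 113000 nM, the highest of the three numbers and beyond the scatter from both other compounds. The next compound to be measured is compound 4 `CCC(=O)Nc1cc(C(=O)Nc2ccc(OC)cc2)ccc1OCCCCl`, with 3-chloropropyl in place of isopropyl on an oxygen on an aromatic ring.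

Among the compounds with values here, no measured pair isolates this change. Compound 1 carries the 3-chloropropoxy group and gives 39700 nM, and compound 2 carries it too and gives 5800 nM. Both also differ from compound 3 elsewhere, so they offer only indirect guidance. Compound 2 differs the most and lies furthest away, so compound 1 is the closer guide in this assay. A modest move to a lower number is expected, with the expected change being a 2.3-fold lower number from compound 3 to compound 4 (0.35 log units; beyond the scatter). For compound 4 the estimated value is 50000 nM, with an expected range from 20000 nM to 115000 nM.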

Compound 4, half-maximal cytotoxic concentration: 158000 nM
Estimate against measurement, compound 4: 3.2-fold (0.50 log units) below; measured number above the stated range.
By their numbers in this assay, from the lowest: compound 2; then compound 1; then compounds 3 and 4 (each within the scatter of the next).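

In this assay the change from isopropoxy to 3-chloropropoxy gives a 1.4-fold higher number from compound 3 to compound 4 (0.15 log units; within the scatter) and so shows no shift beyond the scatter at this oxygen on an aromatic ring. Within the data shown here, with 3-chloropropoxy kept in place, propanoylamino in place of nitro on an aromatic carbon gives a 4.0-fold higher number from compound 1 to compound 4 (0.60 log units; beyond the scatter) and is the only single change read so far that lies beyond the scatter. Nothing at hand gives a reason for either step.

As far as these compounds go, whether an amine or a longer chain in place of 3-chloropropyl on this oxygen would also leave the number within the scatter remains open. Also open, from the compounds shown here alone, is whether propanoylamino in place of nitro gives a step of similar size on the core of compound 2.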